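Naphthalene series: lactam replaced by open acetamide chain

The compounds below may be only part of what the source reports. "The series", "measured", "known", "first", "only" and "open" are said of these compounds alone.

Of the compounds shown here, three have been measured in an assay (Ovis aries) for binding affinity to melatonin receptor type 1A (Homo sapiens); on this read-out lower numbers stand for stronger inhibition and higher numbers for weaker inhibition. Compound 1 `COc1ccc2cccc(C3CNC(=O)C3)c2c1` gives 1580 nM, the highest of the three numbers. Compound 2 `COc1ccc2c(c1)OC(CCNC(C)=O)CO2` gives 794 nM, which lies within the usual scatter of the value for compound 1, so the two cannot be told apart. Compound 3 `CC(=O)NCCCc1cccc2c1OCCO2` gives 126 nM, a number lower than that of compound 1 by more than the scatter; this is the only separation among the three that can be taken as real.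

Compound 4 `COc1ccc2cccc(CONC(C)=O)c2c1` has not been measured. It differs from compound 1 in one place: a group of 6 heavy atoms (3 carbon, 1 nitrogen, 2 oxygen; no ring) in place of a group of 6 heavy atoms (4 carbon, 1 nitrogen, 1 oxygen; one five-membered non-aromatic ring with 1 hetero atom), on an aromatic carbon. The five-membered ring of compound 1 is thus opened into a chain that ends in an acetamide, keeping the same count of heavy atoms.

For the measured compounds named here, no pair of measured compounds shows this kind of change, so the size of the step has no direct precedent here. The measured set does show that the chain-type acetamide of compound 3 sits at 126 nM, well below compound 1, and compound 4 carries the same acetamide end. The step from compound 1 to compound 4 is therefore expected to go toward a lower number, beyond the scatter, estimated as a 40-fold lower number from compound 1 to compound 4 (1.60 log units; beyond the scatter). For compound 4 in this assay the expected value is 40 nM, with a range from 4 nM to 400 nM.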

Compound 4, half-maximal inhibitory concentration: 7.94 nM
For compound 4 the middle estimate is 5.0-fold (0.70 log units) above the measured one, within the range that was stated.
By their numbers in this assay, from the lowest: compound 4; then compound 3; then compounds 2 and 1 (each within the scatter of the next).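

In this assay, for the compounds shown here, the step from the 5-oxopyrrolidin-3-yl group to the open chain ending in an acetamide is a 200-fold lower number from compound 1 to compound 4 (2.30 log units; beyond the scatter) and counts as large, the first readable step at this aromatic carbon of the core. A five-membered ring is therefore not required at this position on the core of compound 1: with the heavy-atom count unchanged, the ringless chain gives a far lower number. The change, however, removes the ring and swaps one carbon for an oxygen in a single step, with the hydrogen-bond acceptors rising from 1 to 2, and nothing at hand accounts for the size of the step or assigns it to either feature.

The compounds shown leave open whether the chain oxygen matters, which a plain carbon chain of the same length carrying the same acetamide end would address. Also open, going by these compounds, are how far this position tolerates a longer chain, and whether an amine or a carboxylic acid at the chain end could stand in for the acetamide.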